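Swapping bromines for methyls on a piperidinyl-amide scaffold

The source may hold more compounds than are shown below. What is called first, only, known or untested is meant among the compounds shown, and "the series" means these compounds.

Of the compounds shown here, two from this series have been tested in a physicochemical assay for permeability, using PAMPA; on this read-out lower numbers stand for lower permeability and higher numbers for higher permeability. Compound 1, `Cc1ccccc1-c1nc(CN2CCC(C(=O)NCCCN3CCC(C)CC3)CC2)c(C)o1`, gives 425 10^-6 cm/s in this assay. Compound 2, `Cc1oc(-c2c(Br)cccc2Br)nc1CN1CCC(C(=O)NCCCN2C[C@H](C)C[C@H](C)C2)CC1`, sits at a limit of this assay rather than at a measured number, with < 1 10^-6 cm/s. That limit, (the limit of < 1 10^-6 cm/s in this assay, at which 1 of the 2 values shown sits), is the lowest reading the assay reports, so compound 2 stands at the floor of what is shown, while compound 1 stands far above it.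

Compound 3, `Cc1cccc(C)c1-c1nc(CN2CCC(C(=O)NCCCN3C[C@H](C)C[C@H](C)C3)CC2)c(C)o1`, is not yet measured. It differs from compound 2 in one place: 2,6-dimethylphenyl in place of 2,6-dibromophenyl on an aromatic carbon. For the measured compounds named here, because no pair of measured compounds differs in just one place, the size of this step cannot be read from the data; it has to be expected. With compound 2 at a limit in this assay, any upward move would be large, and the expectation is that it is large, with the step from compound 2 to compound 3 estimated at an at least 120-fold higher number from compound 2 to compound 3 (2.07 log units; beyond the scatter). Compound 3 is expected to give about 120 10^-6 cm/s in this assay, within a range from 15 10^-6 cm/s to 450 10^-6 cm/s.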

Compound 3, apparent permeability: 254 10^-6 cm/s
Estimate against measurement, compound 3: 2.1-fold (0.33 log units) below; low and high end bracket the measured number.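

In this assay, 2,6-dimethylphenyl in place of 2,6-dibromophenyl on the aromatic carbon of the five-membered ring gives an at least 250-fold higher number from compound 2 to compound 3 (2.40 log units; beyond the scatter). This shows that a change at this one position can by itself shift the read-out by a large amount, which compound 1 and compound 2 could not show, as they differ in more than one place. The two groups match in every count computed for them, with 8 heavy atoms, one six-membered aromatic ring of carbon only, no hydrogen-bond donors or acceptors and no net charge, and the step stays a lower bound, because compound 2 sits at a limit of the assay and not at a number: the limit of < 1 10^-6 cm/s in this assay, at which 1 of the 3 values shown sits.

On these data alone, whether a 2,6-dichlorophenyl group, with chlorine atoms where the bromines stand, or a plain phenyl ring would read closer to compound 2 or to compound 3 remains open. Also open, as far as these compounds go, is whether the same exchange would give a step of similar size with a different amine at the end of the chain, such as a morpholine.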